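A few compounds are considered here, and "the series" means these few. Any claim that something is new, unique, unknown or untested is made for them only; others in the source may bear on it.

Measured so far: compound 1 `CN(C)C/C=C/C(=O)Nc1cccc(S(=O)(=O)N2CCC(NC(=O)c3n[nH]cc3NC(=O)c3c(Cl)cccc3Cl)CC2)c1` and compound 2 `CN(C)C/C=C/C(=O)Nc1cccc(S(=O)(=O)N2CCC(NC(=O)c3n[nH]cc3NC(=O)c3c(Cl)cc(Cl)cc3Cl)CC2)c1`.

In an assay on HEK293 cells for inhibition of cyclin-dependent kinase 14 (Homo sapiens), with a stated time of 4 h (on this read-out lower numbers stand for stronger inhibition and higher numbers for weaker inhibition), compound 1 gives 50 nM. Compound 2 reaches only the assay limit, >= 500 nM in this assay, as recorded in the limit of >= 500 nM in this assay, at which 1 of the 2 values shown sits. Within the data shown here, the single measured step, an at least 10-fold higher number from compound 1 to compound 2 (1.00 log units; beyond the scatter), is the only guide available. Among the measured compounds shown here, compound 3 `COc1cccc(OC)c1C(=O)Nc1c[nH]nc1C(=O)NC1CCN(S(=O)(=O)c2cccc(NC(=O)/C=C/CN(C)C)c2)CC1` differs from compound 2 by 2,6-dimethoxyphenyl in place of 2,4,6-trichlorophenyl on a carbonyl carbon, a change that removes all three chlorines, the one introduced in that step among them. Compound 3 is therefore expected to regain potency relative to compound 2, an estimated step of an at least 6.2-fold lower number from compound 2 to compound 3 (0.79 log units; beyond the scatter). The estimate for compound 3 is 80 nM, within 20 nM to 500 nM. A limit reading cannot be ruled out.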

Compound 3, half-maximal inhibitory concentration: > 1000 nM
Compound 3 was reported as a limit; the forecaster's own chance of this, stated with the estimate: 25%; at least 12-fold (1.09 log units) between middle value and limit.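

In this assay compound 3 gives > 1000 nM, which is a limit and not a number. On this carbonyl carbon, 2,6-dimethoxyphenyl in place of 2,6-dichlorophenyl gives an at least 20-fold higher number from compound 1 to compound 3 (1.30 log units; beyond the scatter), so removing the chlorines does not by itself return the series to the level of compound 1. The step between compound 2 and compound 3 cannot be read, since both values are limits.

Left open is whether 2,6-difluorophenyl or plain phenyl on this carbonyl carbon gives a number rather than a limit.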